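The compounds below may be only part of what the source reports. "The series", "measured", "known", "first", "only" and "open" are said of these compounds alone.

Working notes on the series in a functional assay on HepG2 cells (Homo sapiens) for inhibition, read by MTT assay, with a stated time of 72 h (a lower number here means a stronger inhibitor, a higher number a weaker inhibitor), follow. Compound 1 `Cc1ccc(-c2nnc(SCCCN3CCN(c4nc5ccccc5o4)CC3)o2)cc1` gives 154000 nM with a methyl group, compound 2 `Brc1ccc(-c2nnc(SCCCN3CCN(c4nc5ccccc5o4)CC3)o2)cc1` gives 67500 nM with a bromo group, and compound 3 `Oc1ccc(-c2nnc(SCCCN3CCN(c4nc5ccccc5o4)CC3)o2)cc1` gives 502000 nM with a hydroxy group on the same aromatic carbon of the shared core. Compound 3 holds the highest number of the three and is the weakest inhibitor here, with its steps to both others beyond the scatter.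

Compound 4 `c1ccc(-c2nnc(SCCCN3CCN(c4nc5ccccc5o4)CC3)o2)cc1` has hydrogen in place of hydroxy on an aromatic carbon, para to a large group, which reads as 4-hydroxyphenyl to phenyl (hydrogen in place of hydroxy on an aromatic carbon). Among the measured compounds shown here, two measured steps bear on it, a 3.3-fold higher number from compound 1 to compound 3 (0.51 log units; beyond the scatter) and a 7.4-fold higher number from compound 2 to compound 3 (0.87 log units; beyond the scatter) with hydroxy entering each time. The third step of a 2.3-fold lower number from compound 1 to compound 2 (0.36 log units; beyond the scatter) shows that methyl and bromo also stand apart. For the measured compounds named here, no compound with hydrogen at this place has been measured, so the expectation rests on these steps alone. A modest step to a lower number is expected in this assay with compound 4 landing nearer compound 1 than compound 3. The expected step is a 3.3-fold lower number from compound 3 to compound 4 (0.52 log units; beyond the scatter) by this estimate. The estimated value for compound 4 is 150000 nM within an expected range from 60000 nM to 380000 nM.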

Compound 4, half-maximal inhibitory concentration: 102000 nM
For compound 4 the middle estimate is 1.5-fold (0.17 log units) above the measured one; measured number inside the range.
By their numbers in this assay, from the lowest: compounds 2, 4 and 1 (each within the scatter of the next, the first and the last beyond it); then compound 3.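

Read against hydrogen, the effect at this aromatic carbon, para to a large group, now separates by group: in this assay, losing hydroxy gives a 4.9-fold lower number from compound 3 to compound 4 (0.69 log units; beyond the scatter), so the weak result for compound 3 is a departure from the phenyl compound and not only from the methyl and bromo compounds. Bromo and methyl do not stand apart from hydrogen, with a 1.5-fold higher number from compound 2 to compound 4 (0.18 log units; within the scatter) and a 1.5-fold lower number from compound 1 to compound 4 (0.18 log units; within the scatter), so among the four groups shown only hydroxy gives a step from hydrogen beyond the scatter, and the gap between compound 1 and compound 2 cannot be assigned as a clear effect of either group relative to hydrogen. Nothing on hand accounts for the step seen with hydroxy.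

The compounds shown leave open whether the step depends on the hydroxy hydrogen or on the oxygen itself, a question that a methoxy group or an amine at the same carbon would address. They also leave open whether any group here, such as a carboxylic acid or a trifluoromethyl group, would move the number clearly below that of the phenyl compound, or whether changes elsewhere on the shared core, such as a longer chain, would matter more.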